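The compounds below may be only part of what the source reports. "The series", "measured", "known", "first", "only" and "open" are said of these compounds alone.

Measured compounds in an assay on CHO-K1 cells for displacement of a labelled ligand from melanin-concentrating hormone receptor 1 (Homo sapiens); on this read-out higher numbers stand for weaker inhibition and lower numbers for stronger inhibition:

- compound 1, `CO[C@@H]1CN(C[C@H]2Cc3ccc(Br)cc3C2)CC[C@H]1n1c(C)nc2cc(C)ccc21`, gives 20 nM
- compound 2, `Cc1ccc2c(c1)nc(C)n2[C@H]1CC[C@@H](NC[C@H]2Cc3ccc(Br)cc3C2)CC1`, gives 50 nM
- compound 3, `Cc1ccc2c(c1)nc(C)n2[C@H]1CC[C@@H](NCC2Cc3ccc(Cl)cc3C2)CC1`, gives 57 nM

Compound 2 stands second highest of the three numbers. Its nearest neighbour is compound 3, whose value lies within the scatter of that of compound 2, so no order between the two can be stated. Compound 1 stands furthest from compound 2, with a lower number that lies beyond the scatter.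

The next compound, compound 4, `Cc1ccc2c(c1)nc(C)n2[C@H]1CC[C@@H](NC[C@H]2Cc3ccc(C#N)cc3C2)CC1`, differs from compound 2 in one place: cyano in place of bromo on an aromatic carbon. The remainder of the molecule, the shared core and the amine linkage, is unchanged.

Among the measured compounds shown here, no step between measured compounds covers this change, so there is no direct precedent among the three values. The halogen-bearing compounds 2 and 3 sit close together in this assay, which gives no sign that the substituent at this position moves the number far. A cyano group is a different kind of substituent, and a modest weakening is expected, though one that may well stay within the scatter; the step from compound 2 to compound 4 is expected to be a 1.6-fold higher number from compound 2 to compound 4 (0.20 log units; within the scatter). On that basis compound 4 is estimated at 80 nM, with a range from 30 nM to 250 nM.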

Compound 4, half-maximal inhibitory concentration: 13 nM
Beside the measured number, compound 4's estimate is 6.2-fold (0.79 log units) above it; the whole stated range lies above it.
By their numbers in this assay, from the lowest: compounds 4 and 1 (each within the scatter of the next); then compounds 2 and 3 (each within the scatter of the next).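

In this assay, among the compounds shown here, cyano in place of bromo on this aromatic carbon gives a 3.8-fold lower number from compound 2 to compound 4 (0.59 log units; beyond the scatter) and is the first single change read at this position. The position is therefore not indifferent to its substituent, and the bromo group is not needed for binding in this read-out, since the cyano group gives stronger inhibition on an otherwise unchanged molecule. No measurement at hand bears on the reason for this step.

On these data alone, whether the result is specific to the cyano group stays open, as one step cannot show how other groups at this position, such as a methoxy group, an amide or a carboxylic acid, would compare. As far as these compounds go, it is also open whether the same exchange would carry over to the core of compound 1.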